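This account rests on a few compounds, and the source may have more. Where it says the series, first, only, none or still open, it means among the compounds named here.

In a functional assay on MCF7 cells (Homo sapiens) for antiproliferative activity (a lower number here means a stronger inhibitor, a higher number a weaker inhibitor), compound 3 `CC(C)=CCc1cc(C(=O)Nc2cc3ccc(OCCCNc4ccccc4)c(C)c3oc2=O)ccc1O` is reported only as a limit, > 50000 nM. Two relatives give real numbers: compound 1 `CC(C)=CCc1cc(C(=O)Nc2cc3ccc(OCC4CCN(C)C4)c(C)c3oc2=O)ccc1O` shows 1550 nM and compound 2 `CC(C)=CCc1cc(C(=O)Nc2cc3ccc(OCCCNC4CCCCC4)c(C)c3oc2=O)ccc1O` shows 1070 nM, and a 1.4-fold lower number from compound 1 to compound 2 (0.16 log units; within the scatter) stays within the scatter. Compound 4 `CC(C)=CCc1cc(C(=O)Nc2cc3ccc(OCCCNCc4ccccc4)c(C)c3oc2=O)ccc1O` makes one change to compound 3: benzyl in place of phenyl on an amine nitrogen. The closest measured change is phenyl in place of cyclohexyl on that nitrogen, an at least 46-fold higher number from compound 2 to compound 3 (1.66 log units; beyond the scatter), and an at least 32-fold higher number from compound 1 to compound 3 (1.50 log units; beyond the scatter) is also large. Benzyl, like cyclohexyl, joins the nitrogen through a saturated carbon, so much of that loss is expected to return. A large move to a lower number is therefore expected in this assay, an estimated at least 20-fold lower number from compound 3 to compound 4 (1.30 log units; beyond the scatter). The estimate for compound 4 is 2500 nM, with an expected range of 900 nM to 15000 nM.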

Compound 4, half-maximal inhibitory concentration: 910 nM
For compound 4 the middle estimate is 2.7-fold (0.44 log units) above the measured one, and the stated range covers the measured number.
By their numbers in this assay, from the lowest: compounds 4, 2 and 1 (each within the scatter of the next). At a limit, above all of these: compound 3.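

In this assay, moving from phenyl to benzyl on the amine nitrogen gives an at least 54-fold lower number from compound 3 to compound 4 (1.73 log units; beyond the scatter), so an aromatic ring on this side chain is tolerated and the loss belongs to the anilino form specifically. The number for compound 3 is only a limit: the limit of > 50000 nM in this assay, at which 1 of the 4 values shown sits.

Benzyl also sits level with the saturated groups, with a 1.2-fold lower number from compound 2 to compound 4 (0.07 log units; within the scatter) and a 1.7-fold lower number from compound 1 to compound 4 (0.23 log units; within the scatter). Still open, as far as these compounds go, is whether a 2-phenylethyl group on that nitrogen, or a benzyl carrying a methoxy group, would keep this level.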